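A few compounds are considered here, and "the series" means these few. Any claim that something is new, unique, unknown or untested is made for them only; others in the source may bear on it.

Compound 1 `CCCCCCCCCCCCCCCCNC(=O)[C@@H]1CSC(c2cc(OC)c(OC)c(OC)c2)N1` gives 700 nM
Compound 2 `CCCCCCCCCCCCCCCCNC(=O)[C@@H]1CSC(c2ccc(OC)c(OC)c2)N1` gives 500 nM
Compound 3 `CCCCCCCCCCCCCCCNC(=O)[C@@H]1CSC(c2ccc(NC(C)=O)cc2)N1` gives 1000 nM

These values come from a functional assay on WM164 cells (Homo sapiens) for antiproliferative activity, read by sulforhodamine B assay, with a stated time of 48 h (a higher number here means a weaker inhibitor, a lower number a stronger inhibitor), and all lie within the scatter of one another. Compound 3, at 1000 nM, is therefore not separated from compound 1 or compound 2. Compound 4 `CCCCCCCCCCCCCCCCNC(=O)[C@@H]1CSC(c2ccc(NC(C)=O)cc2)N1` differs from compound 3 by methyl in place of hydrogen on a saturated chain carbon, ten or more bonds along the chain from an amide-type nitrogen. Among the compounds with values here, the only measured step, a 1.4-fold lower number from compound 1 to compound 2 (0.15 log units; within the scatter), concerns an aromatic carbon rather than the chain, and it stays within the scatter. Within the data shown here, no measured step isolates a change in the chain, so no shift beyond the scatter, in either direction, is expected in this assay. The estimated 1.3-fold lower number from compound 3 to compound 4 (0.10 log units; within the scatter) therefore stays within the scatter. Compound 4 is expected at 800 nM, with an estimated range from 350 nM to 1800 nM.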

Compound 4, half-maximal inhibitory concentration: 600 nM
Beside the measured number, compound 4's estimate is 1.3-fold (0.12 log units) above it; measured number inside the range.
By their numbers in this assay, from the lowest: compounds 2, 4, 1 and 3 (each within the scatter of the next).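

In this assay, within the data shown here, methyl in place of hydrogen on a saturated chain carbon, ten or more bonds along the chain from an amide-type nitrogen, gives a 1.7-fold lower number from compound 3 to compound 4 (0.22 log units; within the scatter) and so provides the first measured step at this chain position. With the same chain, 4-acetamidophenyl in place of 3,4-dimethoxyphenyl gives a 1.2-fold higher number from compound 2 to compound 4 (0.08 log units; within the scatter) and 4-acetamidophenyl in place of 3,4,5-trimethoxyphenyl gives a 1.2-fold lower number from compound 1 to compound 4 (0.07 log units; within the scatter) so neither change on the saturated ring carbon separates the compounds. No evidence accompanies these results. Going by these compounds, whether a much shorter chain, such as ethyl, or a chain carrying an amine or a carboxylic acid would move the number beyond the scatter remains open.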